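The source may hold more compounds than are shown below. What is called first, only, known or untested is meant among the compounds shown, and "the series" means these compounds.

Working notes on the series. The shared core is kept throughout; compound 1 `CCC1=C(O)c2c(oc(-c3ccccc3)cc2=O)C(CC)(CC)C1=O` carries a plain phenyl on the aromatic carbon. In a functional assay on KB cells (Homo sapiens) for antiproliferative activity, read by sulforhodamine B assay, with a stated time of 3 days (on this read-out lower numbers stand for an effect already at smaller amounts and higher numbers for an effect only at larger amounts of compound), compound 1 gives only a limit, > 236 uM. Compound 2 `CCC1=C(O)c2c(oc(-c3ccc(C)cc3C)cc2=O)C(CC)(CC)C1=O` in this assay gives 41.2 uM, and compound 3 `CCC1=C(O)c2c(oc(-c3ccc(OC)c(F)c3)cc2=O)C(CC)(CC)C1=O` in this assay gives 26.7 uM. The step of an at least 5.7-fold lower number from compound 1 to compound 2 (0.75 log units; beyond the scatter) and the step of an at least 8.8-fold lower number from compound 1 to compound 3 (0.94 log units; beyond the scatter) are both beyond the scatter, though both rest on the limit of > 236 uM in this assay, at which 1 of the 3 values shown sits, and so have no fixed size. The step of a 1.5-fold lower number from compound 2 to compound 3 (0.19 log units; within the scatter) is within the scatter, so compound 2 and compound 3 cannot be set apart. Compound 3 holds the lowest of the two numbers, with compound 2 nearest.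

For the measured compounds named here, compound 4 `CCC1=C(O)c2c(oc(-c3ccc(F)c(C)c3)cc2=O)C(CC)(CC)C1=O` awaits measurement. 4-fluoro-3-methylphenyl in place of 3-fluoro-4-methoxyphenyl on an aromatic carbon Both substituted aryls measured so far, in compound 2 and compound 3, gave numbers within the scatter of one another, and no measured step separates a methyl from a methoxy on this ring. The step of a 1.1-fold higher number from compound 3 to compound 4 (0.05 log units; within the scatter) is therefore expected to stay within the scatter. Compound 4 is expected in this assay to give about 30 uM, with a range from 12 uM to 75 uM.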

Compound 4, concentration for half-maximal effect: 40.5 uM
For compound 4 the middle estimate is 1.4-fold (0.13 log units) below the measured one; the range from low to high includes it.
By their numbers in this assay, from the lowest: compounds 3, 4 and 2 (each within the scatter of the next). At a limit, above all of these: compound 1.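

In this assay the step of a 1.5-fold higher number from compound 3 to compound 4 (0.18 log units; within the scatter) and the step of a 1.0-fold lower number from compound 2 to compound 4 (0.01 log units; within the scatter) are both within the scatter, so the three substituted aryls cannot be set apart. A number of this size therefore does not depend on the methoxy, which compound 2 and compound 4 lack, or on a fluorine, which compound 2 lacks. The step of an at least 5.8-fold lower number from compound 1 to compound 4 (0.76 log units; beyond the scatter) is beyond the scatter, like the two earlier steps away from the plain phenyl, but it rests on a limit and has no fixed size: the limit of > 236 uM in this assay, at which 1 of the 4 values shown sits.

The compounds shown leave open whether a single substituent on the phenyl would suffice, and whether an amine, a carboxylic acid or a longer chain on this aryl would move the number beyond the scatter. They also leave open what the ethyl groups of the shared core contribute.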